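Sulfur-linked phenyl replaces aryl ether on the chain carbon

The source may hold more compounds than are shown below. What is called first, only, known or untested is meant among the compounds shown, and "the series" means these compounds.

Three members of this series have numbers in an assay for inhibition of Thromboxane-A synthase (Homo sapiens), using microsomes; a higher number here means a weaker inhibitor, a lower number a stronger inhibitor. Compound 1 `O=C(O)CC/C=C\CC1COC(c2ccc(C(F)(F)F)cc2)OC1c1cccnc1` gives 44 nM. Compound 2 `CSc1ccc(OC(C)(C)C2OCC(C/C=C\CCC(=O)O)C(c3cccnc3)O2)c([N+](=O)[O-])c1` gives 22 nM. Going by the values given here, compound 3 `Cc1ccc(C#N)c(OC(C)(C)C2OCC(C/C=C\CCC(=O)O)C(c3cccnc3)O2)c1` gives 50 nM, the highest of the three numbers: its gap to compound 1 lies within the scatter, while the single measured step, a 2.3-fold higher number from compound 2 to compound 3 (0.36 log units; beyond the scatter), is modest but beyond the scatter.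

Compound 4 `CC(C)(Sc1ccccc1)C1OCC(C/C=C\CCC(=O)O)C(c2cccnc2)O1` is not yet measured. It differs from compound 3 in one place: a group of 7 heavy atoms (6 carbon, 1 sulfur; one six-membered aromatic ring of carbon only) in place of a group of 10 heavy atoms (8 carbon, 1 nitrogen, 1 oxygen; one six-membered aromatic ring of carbon only), on a saturated chain carbon bound to two saturated chain carbons and a saturated ring carbon. Among the compounds with values here, the only measured step that touches the same region is a 2.3-fold higher number from compound 2 to compound 3 (0.36 log units; beyond the scatter), a group of 9 heavy atoms in place of a group of 11 heavy atoms on an oxygen on a saturated carbon. Within the data shown here, a group carrying sulfur in place of one carrying oxygen and a triple bond has no direct precedent among the three compounds, and compound 1, whose aryl group is attached without any linking atom, sits within the scatter of compound 3. Whenever this part of the molecule has changed, the number has moved by a modest amount at most, so a step of similar size in either direction, or none beyond the scatter, is expected in this assay. The estimated step is a 1.1-fold lower number from compound 3 to compound 4 (0.05 log units; within the scatter). Compound 4 is therefore expected at 45 nM, with a range from 15 nM to 140 nM.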

Compound 4, half-maximal inhibitory concentration: 40 nM
The estimate for compound 4 lay 1.1-fold (0.05 log units) above the measured number; the range from low to high includes it.
By their numbers in this assay, from the lowest: compounds 2, 4, 1 and 3 (each within the scatter of the next, the first and the last beyond it).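

At this position, on a saturated chain carbon bound to two saturated chain carbons and a saturated ring carbon, this assay gives a 1.3-fold lower number from compound 3 to compound 4 (0.10 log units; within the scatter). This step lies within the scatter, so replacing the group with a nitrile and its triple bond by phenylsulfanyl, which has neither that triple bond nor any substituent on its ring, leaves no readable change in the number. The second new step, a 1.1-fold lower number from compound 1 to compound 4 (0.04 log units; within the scatter), also lies within the scatter, so the change on the saturated ring carbon, which exchanges the group holding three fluorine atoms for the one holding sulfur, cannot be read as a change either. No available evidence bears on this result.

The compounds shown leave open what the linking sulfur itself contributes, as no phenoxy group or sulfonyl-linked phenyl stands on this carbon to set against phenylsulfanyl. They also leave open whether a nitro or methylsulfanyl group on the phenyl ring of phenylsulfanyl would move the number beyond the scatter in this assay.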